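Dropping One Methoxy Group: What Growth Inhibition to Expect

The source may report more compounds than this note shows. Statements on the series, on what has been measured and on what is new or still open speak of the compounds shown alone.

Compound 1 `COc1cc(-c2cc(/C=C/C(=O)c3ccc(N)cc3)[nH]n2)cc(OC)c1OC` was tested in a functional assay on A549 cells (Homo sapiens) for inhibition, read by sulforhodamine B assay, with a stated time of 48 h (on this read-out lower numbers stand for stronger inhibition of growth and higher numbers for weaker inhibition of growth), where compound 1 gives 2080 nM. Among the three measured compounds this is the second highest number: compound 2 `COc1ccc(-c2cc(/C=C/C(=O)c3ccc(OC)c(OC)c3)[nH]n2)cc1` gives 1880 nM, within the scatter of compound 1, while compound 3 `COc1cc(-c2cc(/C=C/C(=O)c3ccc(Cl)c(Cl)c3)[nH]n2)cc(OC)c1OC` gives 18700 nM. Among the compounds with values here, the only measured single change, a 9.0-fold higher number from compound 1 to compound 3 (0.95 log units; beyond the scatter), concerns the group on the carbonyl side of the shared core. Compound 4 `COc1ccc(-c2cc(/C=C/C(=O)c3ccc(N)cc3)[nH]n2)cc1OC` differs from compound 1 elsewhere: hydrogen in place of methoxy on an aromatic carbon. Within the data shown here, no measured step touches this kind of change, so nothing points to a step beyond the scatter in this assay in either direction. Compound 4 is therefore expected to give about 2500 nM, with a range from 900 nM to 7000 nM, which would mean a 1.2-fold higher number from compound 1 to compound 4 (0.08 log units; within the scatter).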

Compound 4, concentration for 50% growth inhibition: 2750 nM
The estimate for compound 4 lay 1.1-fold (0.04 log units) below the measured number; measured number inside the range.
By their numbers in this assay, from the lowest: compounds 2, 1 and 4 (each within the scatter of the next); then compound 3.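

Hydrogen in place of methoxy on this aromatic carbon gives a 1.3-fold higher number from compound 1 to compound 4 (0.12 log units; within the scatter) in this assay, so this methoxy group can go without a step beyond the scatter. This holds for one pair only, in which the 4-aminophenyl group on the carbonyl stays in place. Nothing measured here explains the result.

Still open, on these data alone, is what a hydroxyl group, a fluorine atom or an ethoxy group would give at this place. As far as these compounds go, it is also open whether the same change would give a similar step with the 3,4-dichlorophenyl group of compound 3.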